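Removing the Amide from an Inactive Cyclopentyl Analogue

The source may report more compounds than this note shows. Statements on the series, on what has been measured and on what is new or still open speak of the compounds shown alone.

Compound 1 `CCC1C(=O)N(C)c2cnc(-n3ccc4cc(C(=O)NCC(C)C)ccc43)nc2N1c1ccn(C)n1`: 5070 nM
Compound 2 `CCCCNC(=O)c1ccc2c(ccn2-c2ncc3c(n2)N(c2ccn(C)n2)C(CC)C(=O)N3C)c1`: 8670 nM
Compound 3 `CC[C@@H]1C(=O)N(C)c2cnc(-n3ccc4cc(C(=O)NCC(C)C)ccc43)nc2N1C1CCCC1`: "not active" (no number reported)

In a functional assay on Huh-7 cells (Homo sapiens) for antiproliferative activity, read by CCK-8 assay, with a stated time of 72 h (on this read-out higher numbers stand for weaker inhibition of growth and lower numbers for stronger inhibition of growth), compound 1 gives 5070 nM and compound 2 gives 8670 nM, a step of a 1.7-fold higher number from compound 1 to compound 2 (0.23 log units; within the scatter). Compound 3 in this assay is recorded as "not active" (no number reported), with no number to anchor it. Compound 4 `CC[C@@H]1C(=O)N(C)c2cnc(-n3ccc4ccccc43)nc2N1C1CCCC1` differs from compound 3 by hydrogen in place of isobutylcarbamoyl on an aromatic carbon. Going by the values given here, no measured step bears directly on this change: the step from compound 1 to compound 2 only alters the chain on the amide nitrogen and keeps the group itself. Since compound 3 already shows "not active" (no number reported) in this assay, compound 4 is not expected to gain growth inhibition, and a further report without a number is the most likely outcome. Compound 4 is estimated at 30000 nM, with a range from 8000 nM to 100000 nM.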

Compound 4, concentration for 50% growth inhibition: 4690 nM
The estimate for compound 4 lay 6.4-fold (0.81 log units) above the measured number; the whole stated range lies above it.
By their numbers in this assay, from the lowest: compounds 4, 1 and 2 (each within the scatter of the next).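

In this assay compound 3 is recorded as "not active" (no number reported) and compound 4 gives 4690 nM, so no step can be read between them. Nothing shown accounts for this result. The compounds shown leave open how large the effect of losing the isobutylcarbamoyl group is.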